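The source may hold more compounds than are shown below. What is called first, only, known or untested is meant among the compounds shown, and "the series" means these compounds.

In a functional assay (blood) for inhibition, with Homo sapiens as the target (a higher number here means a weaker inhibitor, a lower number a stronger inhibitor), compound 3 `Cc1nc2ccc(COc3ccc4c(c3)c(SC(C)(C)C)c(CC(C)(C)C(=O)O)n4Cc3ccc(Cl)cc3)cc2s1` gives > 3000 nM, which is a limit and not a number. Compound 1 `CC(C)(C)Sc1c(CC(C)(C)C(=O)O)n(Cc2ccc(Cl)cc2)c2ccc(CCc3ccc4ccccc4n3)cc12` gives > 3000 nM, which is also a limit. Together they stand at the limit of > 3000 nM in this assay, at which 2 of the 3 values shown sit. Compound 2 `CC(C)(C)Sc1c(CC(C)(C)C(=O)O)n(Cc2ccc(Cl)cc2)c2ccc(OCc3ccc4cc(F)ccc4n3)cc12` gives a true number, 880 nM.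

Compound 4 `CC(COc1ccc2c(c1)c(SC(C)(C)C)c(CC(C)(C)C(=O)O)n2Cc1ccc(Cl)cc1)c1ccccn1` carries 1-(pyridin-2-yl)ethyl in place of 2-methyl-1,3-benzothiazol-6-yl on a saturated chain carbon bound to an oxygen on an aromatic ring.

Among the compounds with values here, two measured steps bear on this change. The one at the same place is an at least 3.4-fold higher number from compound 2 to compound 3 (0.53 log units; beyond the scatter), which shows that the group held there can matter. The other is a step that the two limits leave unreadable from compound 1 to compound 3, and it gives no size to work with. Neither step tests the entering group, so the data point to no direction. The expected outcome is no clear step beyond the scatter, written as a number no higher from compound 3 to compound 4 (the limit leaves the size open). For compound 4 the estimated value is 3000 nM, with an expected range from 1000 nM to 9000 nM.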

Compound 4, half-maximal inhibitory concentration: 270 nM
Compound 4: middle estimate off by 11-fold (1.05 log units), on the high side; the measured number lies below the stated range.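

In this assay, the group on the saturated chain carbon bound to an oxygen on an aromatic ring can strengthen inhibition as well as weaken it: 1-(pyridin-2-yl)ethyl gives an at least 11-fold lower number from compound 3 to compound 4 (1.04 log units; beyond the scatter) and a 3.3-fold lower number from compound 2 to compound 4 (0.51 log units; beyond the scatter), so this group with a single aromatic ring outperforms both groups with two rings in these pairs. The larger change, which replaces the whole group on an aromatic carbon, gives an at least 11-fold lower number from compound 1 to compound 4 (1.04 log units; beyond the scatter). Two of these steps start from a limit and not from a number: the limit of > 3000 nM in this assay, at which 2 of the 4 values shown sit.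

The compounds shown leave open whether the gain belongs to the pyridine ring or to the branched ethyl chain. Comparing 1-phenylethyl and pyridin-2-ylmethyl at the same place would separate these two parts.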